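Methoxy in place of methylamino: compound 3 expectation

The source may hold more compounds than are shown below. What is called first, only, known or untested is meant among the compounds shown, and "the series" means these compounds.

Measured so far in a functional assay on MCF7 cells (Homo sapiens) for cytotoxicity, read by MTT assay, with a stated time of 48 h; a higher number here means a weaker inhibitor, a lower number a stronger inhibitor:
compound 1 `Nc1cccc(-c2cnc3[nH]cc(-c4ccncc4)c3c2)c1`, compound 1 gives 2300 nM
compound 2 `CNc1cccc(-c2cnc3[nH]cc(-c4ccncc4)c3c2)c1`, compound 2 gives 4500 nM

Going by the values given here, compound 2 stands at the upper end of the two numbers, yet the only step that separates it from compound 1, a 2.0-fold higher number from compound 1 to compound 2 (0.29 log units; within the scatter), lies within the scatter, so the two compounds are not distinguished by this assay.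

Compound 3 `COc1cccc(-c2cnc3[nH]cc(-c4ccncc4)c3c2)c1` differs from compound 2 by methoxy in place of methylamino on an aromatic carbon. Among the compounds with values here, the one measured step that touches this position, a 2.0-fold higher number from compound 1 to compound 2 (0.29 log units; within the scatter), changed the substituent on that nitrogen without moving the number beyond the scatter. Within the data shown here, no measured pair replaces the nitrogen itself by oxygen or removes the hydrogen-bond donor, so the step to compound 3 has no direct precedent. Given that the nearby change was silent, the working expectation is a step no larger than the scatter, with no clear direction, expected as a 1.1-fold higher number from compound 2 to compound 3 (0.05 log units; within the scatter). Compound 3 is therefore estimated at 5000 nM, with the expected range running from 1500 nM to 16000 nM.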

Compound 3, half-maximal inhibitory concentration: 11700 nM
Beside the measured number, compound 3's estimate is 2.3-fold (0.37 log units) below it, within the range that was stated.
By their numbers in this assay, from the lowest: compounds 1 and 2 (each within the scatter of the next); then compound 3.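

In this assay, methoxy in place of methylamino on the aromatic carbon gives a 2.6-fold higher number from compound 2 to compound 3 (0.41 log units; beyond the scatter), whereas methyl in place of hydrogen on the nitrogen gave only a 2.0-fold higher number from compound 1 to compound 2 (0.29 log units; within the scatter), so this position is not insensitive to change. Methoxy in place of amino gives a similar reading, with a 5.1-fold higher number from compound 1 to compound 3 (0.71 log units; beyond the scatter), and places compound 3 apart from both nitrogen-bearing compounds, although this rests on a single oxygen-bearing compound. The step coincides with a fall in hydrogen-bond donors from 1 on methylamino to 0 on methoxy, but nothing available accounts for the shift.

Open, from the compounds shown here alone, is whether hydroxyl or dimethylamino on this aromatic carbon would read with compounds 1 and 2 or with compound 3, a comparison that would separate the exchange of nitrogen for oxygen from the loss of the donor. Also open, going by these compounds, is whether ethoxy or a longer alkoxy chain would continue the shift seen with methoxy or leave the number unchanged.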